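The source may report more compounds than this note shows. Statements on the series, on what has been measured and on what is new or still open speak of the compounds shown alone.

Compound 1, `Fc1ccc(-c2csc(N/N=C/c3cccs3)n2)cc1`: 35.2 ug/mL
Compound 2, `Fc1ccc(-c2csc(N/N=C/c3ccc(Cl)cc3Cl)n2)cc1`: 35.5 ug/mL

Both compounds were tested in a functional assay, read by spectrophotometry; on this read-out higher numbers stand for weaker inhibition and lower numbers for stronger inhibition. Compound 2 gives 35.5 ug/mL and compound 1 gives 35.2 ug/mL; these two numbers lie within the usual scatter of each other, so the two compounds cannot be told apart on this read-out, and compound 2 stands level with compound 1 rather than above or below it. The two structures differ in more than one place, so nothing can be said about what any single change does between them.

Compound 3, `Clc1ccc(-c2csc(N/N=C/c3ccc(Cl)cc3Cl)n2)cc1`, has not yet been measured. It differs from compound 2 in one place: chloro in place of fluoro on an aromatic carbon. Cut one bond further out, the same difference reads 4-fluorophenyl to 4-chlorophenyl. Going by the values given here, only one halogen is swapped for another of the same kind of position, and no measured pair shows what such a swap does here. The step in this assay from compound 2 to compound 3 is therefore expected to be small, in either direction, and most likely no larger than the scatter. Compound 3 is expected to give about 30 ug/mL, with a likely range from 15 ug/mL to 70 ug/mL. This estimate means a step of a 1.2-fold lower number from compound 2 to compound 3 (0.07 log units; within the scatter), expected to stay within the scatter.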

Compound 3, half-maximal inhibitory concentration: 43.5 ug/mL
Compound 3: the middle estimate sits 1.5-fold (0.16 log units) below what was measured; measured number inside the range.
By their numbers in this assay, from the lowest: compounds 1, 2 and 3 (each within the scatter of the next).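

Going by these compounds alone, the first single change that can be read in this assay is chloro in place of fluoro on an aromatic carbon, para to a large group, and the step of a 1.2-fold higher number from compound 2 to compound 3 (0.09 log units; within the scatter) means that the two compounds cannot be told apart. At this position, then, 4-fluorophenyl and 4-chlorophenyl read as level on this measurement, something the earlier pair could not show, since compound 1 and compound 2 differ in more than one place. No supporting measurement is available to explain this result.

Both groups compared here are single halogens, so the result says nothing about what an amine, a carboxylic acid or a longer chain such as a butyl group would do at this position. As far as these compounds go, it also remains open whether the same swap would read the same way on the structure of compound 1, whose other end differs from that of compound 2 and compound 3.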